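The source may hold more compounds than are shown below. What is called first, only, known or untested is meant among the compounds shown, and "the series" means these compounds.

Measured compounds in the series:

compound 1 `COc1ccccc1CNC(=O)SC[C@H](NC(C)=O)C(=O)O`: > 200000 nM
compound 2 `COc1ccccc1NC(=O)SC[C@H](NC(C)=O)C(=O)O`: > 200000 nM
compound 3 `CC(=O)N[C@@H](CSC(=O)Nc1ccccc1)C(=O)O`: 153000 nM

All three were run in a functional assay on OVCAR-3 cells (Homo sapiens) for cytotoxicity, read by MTT assay, with a stated time of 6 days; a lower number here means a stronger inhibitor, a higher number a weaker inhibitor. For compound 2 the figure is a limit of the assay, not a number. The same holds for compound 1, whose figure is also a limit. Within the data shown here, compound 3 is the only member with an actual number. Among the measured compounds shown here, the step of an at least 1.3-fold lower number from compound 2 to compound 3 (0.11 log units; that floor lies within the scatter) is the sole measured change in one place, and its floor lies within the scatter; moreover it starts from the limit of > 200000 nM in this assay, at which 2 of the 3 values shown sit, so its true size is not known. Compound 2 thus stands at the upper edge of what the assay can report, together with compound 1.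

Compound 4 `COc1ccc(OC)c(NC(=O)SC[C@H](NC(C)=O)C(=O)O)c1` differs from compound 2 by methoxy in place of hydrogen on an aromatic carbon; the entering methoxy sits para to a methoxy group. For the measured compounds named here, no measured step adds a methoxy, and the one step that removes one gives only a floor within the scatter. Nothing here points to a change beyond the scatter in either direction, and since compound 2 is already at the limit, compound 4 is expected to stay there or near it. The expected step is a step that the limit leaves unreadable from compound 2 to compound 4. Compound 4 is estimated at 250000 nM, within 100000 nM to 600000 nM.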

Compound 4, half-maximal inhibitory concentration: > 200000 nM
Compound 4: only a limit was reported (the forecaster's own chance of this, stated with the estimate: 75%); the middle value lies beyond the limit too.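

In this assay compound 2 and compound 4 both sit at a limit and not at an actual number, so the step between them cannot be read: the limit of > 200000 nM in this assay, at which 3 of the 4 values shown sit.

Left open is whether methoxy in place of hydrogen on an aromatic carbon changes cytotoxicity at all in this series; compound 3 alone carries an actual number.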